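The source may hold more compounds than are shown below. What is called first, only, known or untested is meant among the compounds shown, and "the series" means these compounds.

Measured so far:
compound 1 `Cc1cc(S(=O)(=O)/N=C(\N)n2nccc2-c2ccccc2)c(SCc2cccc(Cl)c2)cc1Cl` — 10000 nM
compound 2 `Cc1cc(-c2ccccc2)n(/C(N)=N/S(=O)(=O)c2cc(C)c(Cl)cc2SCc2cccc(C(F)(F)F)c2)n1` — 40000 nM
compound 3 `Cc1cc(-c2ccccc2)n(/C(N)=N/S(=O)(=O)c2cc(C)c(Cl)cc2SCc2cccc(Cl)c2)n1` — 18000 nM

In an ADME assay on HaCaT cells (Homo sapiens) for cytotoxicity, read by MTT assay, with a stated time of 72 h (a higher number here means a weaker inhibitor, a lower number a stronger inhibitor), compound 1 gives the lowest of the three numbers; its nearest neighbour is compound 3, a 1.8-fold higher number from compound 1 to compound 3 (0.26 log units; within the scatter), and its furthest compound 2, a gap beyond the scatter. Compound 4 `Cc1cc(S(=O)(=O)/N=C(\N)n2nccc2-c2ccccc2)c(SCc2ccccc2Cl)cc1Cl` differs from compound 1 by 2-chlorophenyl in place of 3-chlorophenyl on a saturated chain carbon bound to a sulfur. Going by the values given here, no measured step moves the chlorine around that ring. Among the compounds with values here, the one step on that ring, a 2.2-fold lower number from compound 2 to compound 3 (0.35 log units; beyond the scatter), is modest and swaps the group rather than its place; the step of a 1.8-fold higher number from compound 1 to compound 3 (0.26 log units; within the scatter) sits elsewhere on the core. The move of the chlorine is therefore expected to give a 1.2-fold higher number from compound 1 to compound 4 (0.08 log units; within the scatter), no step beyond the scatter. Compound 4 is estimated at 12000 nM, range 5000 nM to 30000 nM.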

Compound 4, half-maximal inhibitory concentration: 20000 nM
Beside the measured number, compound 4's estimate is 1.7-fold (0.22 log units) below it, within the range that was stated.
By their numbers in this assay, from the lowest: compounds 1, 3, 4 and 2 (each within the scatter of the next, the first and the last beyond it).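

Here the place of the chlorine varies, not the group: 2-chlorophenyl in place of 3-chlorophenyl on a saturated chain carbon bound to a sulfur gives a 2.0-fold higher number from compound 1 to compound 4 (0.30 log units; within the scatter) in this assay. The two chlorophenyl groups are therefore not separated in this assay, whereas the group swap at this position gave a 2.2-fold lower number from compound 2 to compound 3 (0.35 log units; beyond the scatter). No available evidence bears on this result.

From the compounds shown here alone, whether the same move holds on the core of compound 3 remains open. Also open, going by these compounds, is how a methoxy group or a carboxylic acid in place of the chlorine would read.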